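The compounds below may be only part of what the source reports. "The series", "measured", "known", "first", "only" and "open" are said of these compounds alone.

Three compounds share one core and differ only in the group on a saturated chain carbon bound to an oxygen next to a carbonyl group. In a physicochemical assay, read by HPLC, in phosphate buffer, with a stated time of 2 h, at pH 7.4 (a lower number here means that less of the compound is left, a higher number that more of the compound is left), compound 1 `C[C@@H]1CN(C(=O)c2nc(Nc3cc(C4CC4)[nH]n3)c3cc(Cl)ccc3n2)CCN1C(=O)OCc1ccccc1` gives 97.7%. Compound 2 `COC(=O)N1CCN(C(=O)c2nc(Nc3cc(C4CC4)[nH]n3)c3cc(Cl)ccc3n2)C[C@H]1C` gives 100% in this assay, and compound 3 `C[C@@H]1CN(C(=O)c2nc(Nc3cc(C4CC4)[nH]n3)c3cc(Cl)ccc3n2)CCN1C(=O)OCC(Cl)(Cl)Cl` gives 98.7%. Compound 3 is separated from compound 1 by a number 1 percentage points higher from compound 1 to compound 3 (within the scatter) and from compound 2 by a number 1.3 percentage points lower from compound 2 to compound 3 (within the scatter), so all three numbers lie within the scatter of one another, as does a number 2.3 percentage points higher from compound 1 to compound 2 (within the scatter).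

Compound 4 `C[C@@H]1CN(C(=O)c2nc(Nc3cc(C4CC4)[nH]n3)c3cc(Cl)ccc3n2)CCN1C(=O)OCOC(=O)C(C)(C)C` differs from compound 3 by ((tert-butyl)carbonyl)oxy in place of trichloromethyl on a saturated chain carbon bound to an oxygen next to a carbonyl group. Among the compounds with values here, since every step at this position so far stayed within the scatter, no step beyond it is expected here either, giving an estimated a number 2.7 percentage points lower from compound 3 to compound 4 (within the scatter). Compound 4 is therefore expected to give about 96% in this assay, within a range from 85% to 100%.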

Compound 4, percent of the compound remaining: 97.7%
Beside the measured number, compound 4's estimate is 1.7 percentage points below it; measured number inside the range.
By their numbers in this assay, from the lowest: compounds 1, 4, 3 and 2 (each within the scatter of the next).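

With ((tert-butyl)carbonyl)oxy, which brings a carbonyl of its own and 2 hydrogen-bond acceptors, this position still shows no step beyond the scatter in this assay. The step reads a number 1 percentage points lower from compound 3 to compound 4 (within the scatter) against trichloromethyl, a number 2.3 percentage points lower from compound 2 to compound 4 (within the scatter) against hydrogen and no change at the digits printed from compound 1 to compound 4 (within the scatter) against phenyl. Nothing available here offers an explanation for these results.

From the compounds shown here alone, whether an amine or a carboxylic acid on this saturated chain carbon would also stay within the scatter remains open.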